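This account rests on a few compounds, and the source may have more. Where it says the series, first, only, none or still open, it means among the compounds named here.

In a functional assay on the whole organism (arterial blood) with Rattus norvegicus as the target (a higher number here means that more compound is needed for the effect, a lower number that less compound is needed), compound 1 `Cc1nc2cnccc2n1CC1CCN(C(=O)CC(C)(C)c2ccccc2)CC1` gives 0.012 mg/kg. Compound 2 `Cc1nc2cnccc2n1CC1CCN(C(=O)CCc2ccccc2)CC1` has no exact number, only a limit: compound 2 gives > 5 mg/kg. For the measured compounds named here, the one measured step is an at least 410-fold higher number from compound 1 to compound 2 (2.61 log units; beyond the scatter). This step is large and lies beyond the scatter, but it sits on the saturated chain carbon bound to the carbonyl carbon, so it gives no direct size for a change on the aromatic ring.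

Compound 3 `COc1ccccc1CCC(=O)N1CCC(Cn2c(C)nc3cnccc32)CC1` differs from compound 2 in one place: methoxy in place of hydrogen on an aromatic carbon. In words, this is methoxy in place of hydrogen on an aromatic carbon, ortho to a large group, turning phenyl to 2-methoxyphenyl. Going by the values given here, no measured step covers a change of this kind, so the expectation starts from compound 2 and its limit of > 5 mg/kg. No step beyond the scatter can be expected on these data, and another limit result is quite possible. The estimated step is a number no higher from compound 2 to compound 3 (the limit leaves the size open). Compound 3 is expected at 5 mg/kg, with an estimated range from 1 mg/kg to 20 mg/kg.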

Compound 3, dose for 50% inhibition: 0.045 mg/kg
The estimate for compound 3 lay 110-fold (2.05 log units) above the measured number; the whole stated range lies above it.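

In this assay, methoxy in place of hydrogen on an aromatic carbon gives an at least 110-fold lower number from compound 2 to compound 3 (2.04 log units; beyond the scatter), so the chain of compound 2 is not fixed at the weak end of the series: a change on the ring alone moves it a long way. Compound 2 stands only as a limit, so this step has a lower bound and no exact size: the limit of > 5 mg/kg in this assay, at which 1 of the 3 values shown sits. For the compounds shown here, the 2-methoxybenzyl group still falls short of the 1-methyl-1-phenylethyl group, with a 3.8-fold higher number from compound 1 to compound 3 (0.57 log units; beyond the scatter), yet the two compounds now sit far closer together in this assay than the first step suggested, and a change on the aromatic ring emerges as a second route to low doses besides the change on the chain carbon.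

From the compounds shown here alone, whether this gain belongs to methoxy itself remains open, and ethoxy, hydroxyl or a fluorine atom on the same aromatic carbon would separate the group from the position. Also open, going by these compounds, is whether the two changes add up, which a 2-methoxyphenyl ring on the 1-methyl-1-phenylethyl chain of compound 1 would answer.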